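Acetyl in place of hydroxyl hydrogen on a lactone terpenoid

The compounds below may be only part of what the source reports. "The series", "measured", "known", "first", "only" and "open" are said of these compounds alone.

Compound 1 `CC1=C(CC[C@@H](C)C(=O)CCC2=CC(=O)OC2)C(C)(C)CCC1` gives < 5 ug/mL in a functional assay on ZR-75-30 cells (Homo sapiens) for cytotoxicity, read by MTT assay, with a stated time of 72 h (on this read-out lower numbers stand for stronger inhibition and higher numbers for weaker inhibition), a limit of the assay rather than a number.
Compound 2 `C[C@@H]1C[C@@H](O)[C@H]2C(C)(C)CCC[C@]2(C)[C@@]12CC[C@]1(COC(=O)C1)O2` gives < 5 ug/mL in this assay, again a limit, not a number.
Compound 3 `C[C@@H]1CC=C2C(C)(C)CCC[C@]2(C)[C@@]12CC[C@]1(COC(=O)C1)O2` gives < 5 ug/mL in this assay, also a limit.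

For the measured compounds named here, all three measured values sit at the same point, (the limit of < 5 ug/mL in this assay, at which 3 of the 3 values shown sit), so compound 2 stands at the limit like the others, and no step between measured compounds can be sized. Compound 4 `CC(=O)O[C@@H]1C[C@@H](C)[C@]2(CC[C@]3(COC(=O)C3)O2)[C@@]2(C)CCCC(C)(C)[C@H]12` differs from compound 2 by acetyl in place of hydrogen on an oxygen on a saturated carbon. Going by the values given here, with no measured step to lean on, the expected step that the limit leaves unreadable from compound 2 to compound 4 is none beyond the usual scatter. Compound 4 is therefore estimated at 3 ug/mL, within a range from 1 ug/mL to 9 ug/mL.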

Compound 4, half-maximal inhibitory concentration: < 5 ug/mL
Compound 4: no number, only a limit (the forecaster's own chance of this, stated with the estimate: 55%); the middle value lies beyond the limit too.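

No step from compound 2 to compound 4 can be read, because both results are limits rather than numbers: the limit of < 5 ug/mL in this assay, at which 4 of the 4 values shown sit.

The compounds shown leave open whether going from hydroxy to acetoxy changes the strength of inhibition in this assay at all.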